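A few compounds are considered here, and "the series" means these few. Any claim that something is new, unique, unknown or untested is made for them only; others in the source may bear on it.

Measured compounds:
- compound 1 `C=CCn1c(=O)n(CCCCO)c2nc(N)nc(O)c21`, in a functional assay on the whole organism (B cells) with Mus musculus as the target (a lower number here means a smaller maximal response, a higher number a larger maximal response), compound 1 gives 12%
- compound 2 `CC1OC(n2c(=O)n(C)c3c(O)nc(N)nc32)[C@H](O)[C@@H]1O`, in this assay compound 2 gives 0%
- compound 3 `C=CCn1c(=S)n(C2OC(COCc3ccccc3)[C@H]3OC(C)(C)O[C@@H]23)c2nc(N)nc(O)c21`, in this assay compound 3 gives 77%

Compound 1 stands second highest of the three numbers; compound 2 lies nearest, its number lower by a difference beyond the usual scatter, and compound 3 lies furthest, its number higher by a difference well beyond the scatter.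

The next compound, compound 4 `C=CCn1c(=O)n(C2CCC(CO)C2)c2nc(N)nc(O)c21`, keeps the core of compound 1 and differs from it in one place: a group of 7 heavy atoms (6 carbon, 1 oxygen; one five-membered non-aromatic ring of carbon only) in place of a group of 5 heavy atoms (4 carbon, 1 oxygen; no ring), on an aromatic nitrogen. No comparable single change has been measured in this set, so the direction rests on the shared core alone. The step from compound 1 to compound 4 is expected to be small and upward, a number 8 percentage points higher from compound 1 to compound 4 (within the scatter), within or just beyond the scatter. Compound 4 is estimated at 20%, with a range from 5% to 50%.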

Compound 4, largest response reached (reported as maximal response), in percent of the reference or control that the assay uses: 26%
Compound 4: middle estimate off by 6 percentage points, on the low side; low and high end bracket the measured number.
By their numbers in this assay, from the lowest: compound 2; then compound 1; then compound 4; then compound 3.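

Within the data shown here, at this aromatic nitrogen, the change from 4-hydroxybutyl to the group with a five-membered non-aromatic ring of carbon only gives a number 14 percentage points higher from compound 1 to compound 4 (beyond the scatter) in this assay and is the first single-place step. A ring of carbon only is therefore tolerated at this position, with one hydrogen-bond donor and one acceptor on both groups. Nothing measured here accounts for the rise.

Still open, as far as these compounds go, is whether an open chain of the same size would match the ring. Also open, from the compounds shown here alone, is how a longer chain, or an amine or carboxylic acid in place of the hydroxyl, would change the response.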